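The source may report more compounds than this note shows. Statements on the series, on what has been measured and on what is new or still open speak of the compounds shown alone.

Of the compounds shown here, three have so far been measured in an ADME assay on MT4 cells (Homo sapiens) for cytotoxicity, read by MTT assay, with a stated time of 5 days; a lower number here means that less compound is tolerated, a higher number that more compound is tolerated.

Compound 1 `Cc1cc(C)c(Oc2cc(Nc3ccc(C#N)cc3)ncc2C(=O)NCc2cn(Cc3cccc(Cl)c3)nn2)c(C)c1` gives 187000 nM.
Compound 2 `Cc1cc(C)c(Oc2cc(Nc3ccc(C#N)cc3)ncc2C(=O)NCc2cn(Cc3ccc(F)cc3)nn2)c(C)c1` gives >= 153000 nM, which is a limit of the assay and not a number.
Compound 3 `Cc1cc(C)c(Oc2cc(Nc3ccc(C#N)cc3)ncc2C(=O)NCc2cn(CC(=O)N3CCOCC3)nn2)c(C)c1` gives 181000 nM.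

In this assay compound 3 stands at the lowest of the two numbers, and its nearest neighbour is compound 1, from which it is separated only within the scatter: a 1.0-fold lower number from compound 1 to compound 3 (0.01 log units; within the scatter). Because of the limit at which compound 2 sits (the limit of >= 153000 nM in this assay, at which 1 of the 3 values shown sits), the two steps that involve compound 2 cannot be read: a step that the limit leaves unreadable from compound 1 to compound 2 and a step that the limit leaves unreadable from compound 2 to compound 3.

Compound 4 `CC(=O)Cn1cc(CNC(=O)c2cnc(Nc3ccc(C#N)cc3)cc2Oc2c(C)cc(C)cc2C)nn1` has not yet been measured. It differs from compound 3 at one place: methyl in place of morpholin-4-yl on a carbonyl carbon. Among the compounds with values here, none of the measured steps touches this part of the molecule; all of them exchange the group on the saturated chain carbon bound to the aromatic nitrogen, and the single readable one, a 1.0-fold lower number from compound 1 to compound 3 (0.01 log units; within the scatter), swaps 3-chlorophenyl for (morpholin-4-yl)carbonyl without leaving the scatter. The measured material therefore gives no reason to expect a step beyond the scatter in this assay. Compound 4 is accordingly expected at 180000 nM, within a range from 90000 nM to 360000 nM. Compound 4 is thus expected to show a 1.0-fold lower number from compound 3 to compound 4 (0.00 log units; within the scatter).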

Compound 4, half-maximal cytotoxic concentration: 19400 nM
Compound 4: middle estimate off by 9.3-fold (0.97 log units), on the high side; the whole stated range lies above it.
By their numbers in this assay, from the lowest: compound 4; then compounds 3 and 1 (each within the scatter of the next).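

In this assay, within the data shown here, the group on the carbonyl carbon proves able to move the number: a 9.3-fold lower number from compound 3 to compound 4 (0.97 log units; beyond the scatter), with methyl in place of morpholin-4-yl, and this is the first step to lie beyond the scatter. The earlier readable exchange on the saturated chain carbon bound to the aromatic nitrogen stayed within the scatter, whereas the 2-oxopropyl group does not, as a 9.6-fold lower number from compound 1 to compound 4 (0.98 log units; beyond the scatter) shows, so a carbonyl on that chain does not by itself keep the number where it was, compound 3 having one as well. Compound 2 stands at a limit and not a number, so an at least 7.8-fold lower number from compound 2 to compound 4 (0.89 log units; beyond the scatter) is only a bound, though it points the same way: the limit of >= 153000 nM in this assay, at which 1 of the 4 values shown sits.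

The compounds shown leave open whether the number follows the whole morpholin-4-yl ring, its oxygen or simply the size of the group, which a piperidin-1-yl, a dimethylamino or an ethyl group on the same carbonyl carbon would begin to separate. They also leave open what the carbonyl of the 2-oxopropyl group contributes, which a plain propyl chain in its place would address.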